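The compounds below may be only part of what the source reports. "The series", "measured", "known", "first", "only" and "open" are said of these compounds alone.

Measured compounds in an assay on isolated protein for inhibition of protein kinase C zeta type (Homo sapiens), with stated times of 1 h and 2.5 min, tested at 30 uM; on this read-out lower numbers stand for less inhibition and higher numbers for more inhibition at the one concentration tested (going by the name of the read-out):
compound 1 `COCCOC(=O)c1c(-c2ccc(OC)c(OC)c2)csc1N`, which gives 57%
compound 2 `COc1ccc(-c2csc(N)c2C(=O)OCc2ccccc2)cc1OC`, which gives 100%

Among these two numbers compound 2 stands highest; its nearest neighbour is compound 1, and the step of a number 43 percentage points higher from compound 1 to compound 2 (beyond the scatter) lies beyond the scatter. Compound 3 `COc1ccc(-c2csc(N)c2C(=O)OCc2ccccc2C)cc1OC` differs from compound 2 by methyl in place of hydrogen on an aromatic carbon. Among the measured compounds shown here, only one measured step is at hand, and it bears on this change only indirectly: the step of a number 43 percentage points higher from compound 1 to compound 2 (beyond the scatter) arose from phenyl in place of methoxymethyl on a saturated chain carbon bound to an oxygen next to a carbonyl group, a change in the same region of the molecule but of a different kind. For the measured compounds named here, no measured pair shows a methyl entering an aromatic carbon. Since compound 2 already reaches 100% in this assay, the step of a number 8 percentage points lower from compound 2 to compound 3 (within the scatter) is expected to be small, with a slight downward lean allowed. Compound 3 is therefore expected to give 92% in this assay, within 70% to 100%.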

Compound 3, a percentage reported as inhibition, at one concentration (the size of the read-out at that concentration, not a potency): 64%
The estimate for compound 3 lay 28 percentage points above the measured number, outside the stated range (below it).
By their numbers in this assay, from the lowest: compounds 1 and 3 (each within the scatter of the next); then compound 2.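

In this assay, the benzyl ring proves sensitive to even one added carbon: methyl in place of hydrogen on an aromatic carbon, ortho to a large group, gives a number 36 percentage points lower from compound 2 to compound 3 (beyond the scatter). The high reading of the benzyl group therefore does not carry over to the 2-methylbenzyl group, which stands against the methoxymethyl chain with a number 7 percentage points higher from compound 1 to compound 3 (within the scatter). No measurement at hand accounts for this loss.

As far as these compounds go, it remains open whether the loss belongs to the methyl group itself or to its place, as a methyl on another aromatic carbon of this ring could tell. The compounds shown also leave open how a chlorine, an amine or a carboxylic acid would read at this same place on the ring.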